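A smaller group on the amide nitrogen of compound 1

The source may hold more compounds than are shown below. What is called first, only, known or untested is meant among the compounds shown, and "the series" means these compounds.

Measured so far in an assay on HEK293 cells for agonist activity at transient receptor potential cation channel subfamily M member 8 (Homo sapiens), read by fluorescence and calcium flux, with a stated time of 15 min; on this read-out higher numbers stand for an effect only at larger amounts of compound and lower numbers for an effect already at smaller amounts:
compound 1, `Cc1ccc(OCC(=O)N(Cc2cccs2)C2COC2)cc1`: 23000 nM
compound 2, `CCN(Cc1ccco1)C(=O)COc1ccc(C)cc1`: 489 nM
compound 3, `CCc1ccc(OCC(=O)N(CC)Cc2cccs2)cc1`: 67 nM

Among these three, compound 1 gives the highest number, 23000 nM; compound 2 comes next with a lower number, and compound 3 gives the lowest, both gaps lying beyond the usual scatter. Compound 4, `Cc1ccc(OCC(=O)N(C)Cc2cccs2)cc1`, has not been measured yet. It differs from compound 1 by methyl in place of oxetan-3-yl on an amide-type nitrogen. Within the data shown here, no measured pair shows this exact change, so its size can only be estimated. Compound 1 stands far above the other two numbers in this assay, which leaves room for a downward step. The step of a 15-fold lower number from compound 1 to compound 4 (1.19 log units; beyond the scatter) is expected to lower the number beyond the scatter. For compound 4 the estimate in this assay is 1500 nM, expected to fall between 300 nM and 8000 nM.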

Compound 4, half-maximal effective concentration: 400 nM
The estimate for compound 4 lay 3.8-fold (0.57 log units) above the measured number, and the stated range covers the measured number.
By their numbers in this assay, from the lowest: compound 3; then compounds 4 and 2 (each within the scatter of the next); then compound 1.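

In this assay, methyl in place of oxetan-3-yl on the amide-type nitrogen gives a 58-fold lower number from compound 1 to compound 4 (1.76 log units; beyond the scatter) with the rest of the molecule unchanged. Among these compounds, this is the first reading of this position alone, as the earlier compounds differ from compound 1 in more than one place, and it ties much of the high number of compound 1 to the oxetan-3-yl group. Nothing measured here gives a reason for the size of this step.

On these data alone, whether the ring oxygen or the four-membered ring itself goes with the high number stays open. Cyclobutyl or azetidin-3-yl on this nitrogen would bear on that question.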